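The source may hold more compounds than are shown below. What is called first, only, known or untested is meant among the compounds shown, and "the series" means these compounds.

Measured in a functional assay on SK-BR-3 cells (Homo sapiens) for antiproliferative activity, read by MTT assay, with a stated time of 72 h; on this read-out higher numbers stand for weaker inhibition and lower numbers for stronger inhibition:

- Compound 1 `C/C=C1/[C@H](O[C@@H]2O[C@H](COC(C)=O)[C@@H](OC(C)=O)[C@H](OC(C)=O)[C@H]2OC(C)=O)OC=C(C(=O)OC)[C@H]1CC(=O)OCCCCCCCCCCCCCCC`: 3810 nM
- Compound 2 `C/C=C1/[C@H](O[C@@H]2O[C@H](COC(C)=O)[C@@H](OC(C)=O)[C@H](OC(C)=O)[C@H]2OC(C)=O)OC=C(C(=O)OC)[C@H]1CC(=O)OCCC`: 6600 nM
- Compound 3 `C/C=C1/[C@H](O[C@@H]2O[C@H](COC(C)=O)[C@@H](OC(C)=O)[C@H](OC(C)=O)[C@H]2OC(C)=O)OC=C(C(=O)OC)[C@H]1CC(=O)OCCCC`: > 15000 nM (a limit of the assay, not a number)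

Compound 1 and compound 2 lie within the scatter of each other, as a 1.7-fold higher number from compound 1 to compound 2 (0.24 log units; within the scatter) shows. Compound 1 also stands clear of compound 3, with an at least 3.9-fold higher number from compound 1 to compound 3 (0.59 log units; beyond the scatter).

Compound 4 `C/C=C1/[C@H](O[C@@H]2O[C@H](COC(C)=O)[C@@H](OC(C)=O)[C@H](OC(C)=O)[C@H]2OC(C)=O)OC=C(C(=O)O)[C@H]1CC(=O)OCCCCCCCCCCCCCCC` differs from compound 1 at a single place, with hydrogen in place of methyl on an oxygen next to a carbonyl group, so methoxycarbonyl becomes carboxy (hydrogen in place of methyl on an oxygen next to a carbonyl group).

For the measured compounds named here, none of the measured steps touches this group, as all of them change the saturated chain, so they bear on it only indirectly. Still, a small edit can matter in this set, as the single added methyl in an at least 2.2-fold higher number from compound 2 to compound 3 (0.35 log units; beyond the scatter) shows. A modest move towards weaker inhibition therefore seems likely, though the data do not test this change directly.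

The expected change is a 2.1-fold higher number from compound 1 to compound 4 (0.32 log units; beyond the scatter). For compound 4 the estimated value is 8000 nM, with an expected range from 2500 nM to 25000 nM.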

Compound 4, half-maximal inhibitory concentration: > 20000 nM
Compound 4 was reported as a limit; the forecaster's own chance of this, stated with the estimate: 35%; at least 2.5-fold (0.39 log units) between middle value and limit.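

In this assay compound 4 gives > 20000 nM, a limit of the assay and not a number. Every earlier step changed the saturated chain, whereas here the chain stays the same and methoxycarbonyl becomes carboxy; this single change gives an at least 5.2-fold higher number from compound 1 to compound 4 (0.72 log units; beyond the scatter), so this position on the shared core clearly matters for the read-out. The full size of the step stays unknown, since the reading ends at a limit: the limit of > 20000 nM in this assay, at which 1 of the 4 values shown sits.

With only methoxycarbonyl and carboxy shown at this position, it remains open whether an ethyl ester, an amide or a nitrile there would keep inhibition close to that of compound 1. Going by these compounds, it also remains open whether the same change would act alike on the shorter chain of compound 2.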